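The compounds below may be only part of what the source reports. "The series", "measured", "known", "first", "only" and "open" are said of these compounds alone.

Of the compounds shown here, three sharing one core have been measured in a functional assay on HT-29 cells (Homo sapiens) for antiproliferative activity, read by sulforhodamine B assay, with a stated time of 48 h; on this read-out higher numbers stand for weaker inhibition and lower numbers for stronger inhibition. Compound 1 `O=C1NCCN1c1ccc(S(=O)(=O)Nc2ccc(Br)cc2)cc1` gives 300 nM. Compound 3 `O=C1NCCN1c1ccc(S(=O)(=O)Nc2ccccc2)cc1` gives 280 nM, and its step from compound 1 is a 1.1-fold lower number from compound 1 to compound 3 (0.03 log units; within the scatter), so the two sit together within the scatter. Compound 2 `CC(C)(C)c1ccc(NS(=O)(=O)c2ccc(N3CCNC3=O)cc2)cc1` is reported only as a limit of the assay, > 1000 nM, not as a number. The step from compound 1 to compound 2 is an at least 3.3-fold higher number from compound 1 to compound 2 (0.52 log units; beyond the scatter), and the step back to compound 3 is an at least 3.5-fold lower number from compound 2 to compound 3 (0.55 log units; beyond the scatter).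

Compound 4 `CCCCc1ccc(NS(=O)(=O)c2ccc(N3CCNC3=O)cc2)cc1` differs from compound 3 by butyl in place of hydrogen on an aromatic carbon. Among the compounds with values here, the only measured steps that bear on it are those to and from compound 2, where a bulky alkyl group at the same place produced a number beyond the scatter in the weaker direction, with the value resting on a limit (the limit of > 1000 nM in this assay, at which 1 of the 3 values shown sits). A butyl group is also a larger alkyl chain, so a weaker result is expected for compound 4, of a size near a 3.6-fold higher number from compound 3 to compound 4 (0.55 log units; beyond the scatter). In this assay compound 4 is estimated at 1000 nM, within a range from 400 nM to 3000 nM.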

Compound 4, half-maximal inhibitory concentration: 610 nM
Compound 4: the middle estimate sits 1.6-fold (0.21 log units) above what was measured, within the range that was stated.
By their numbers in this assay, from the lowest: compounds 3 and 1 (each within the scatter of the next); then compound 4. At a limit, above all of these: compound 2.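

In this assay, within the data shown here, butyl in place of hydrogen gives the first full number for an alkyl group at this place, a 2.2-fold higher number from compound 3 to compound 4 (0.34 log units; beyond the scatter), a modest weakening. The same holds against bromo, a 2.0-fold higher number from compound 1 to compound 4 (0.31 log units; beyond the scatter); bromo stayed within the scatter of hydrogen at this place and butyl did not, so the position does not treat every group alike. Compound 2 stands only at a limit. Butyl in place of tert-butyl gives an at least 1.6-fold lower number from compound 2 to compound 4 (0.21 log units; that floor lies within the scatter), and this cannot be read as a real difference between the two groups: the limit of > 1000 nM in this assay, at which 1 of the 4 values shown sits.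

From the compounds shown here alone, whether a shorter chain such as methyl or a longer chain such as hexyl would behave like butyl remains open. So does the effect of an amine or a carboxylic acid at this place.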